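Tolerance in Macrophage Cells for Four Related Compounds

The compounds below may be only part of what the source reports. "The series", "measured", "known", "first", "only" and "open" are said of these compounds alone.

Compound 1, `Brc1cccc(-c2nnc(Cn3nnc4ccccc43)o2)c1`: in an ADME assay on cells (Macrophage, Homo sapiens) for inhibition (a higher number here means that more compound is tolerated, a lower number that less compound is tolerated), compound 1 gives only a limit of the assay, > 100000 nM.
Compound 2, `Brc1ccc(-c2nnc(Cn3nnc4ccccc43)o2)cc1`: in this assay compound 2 gives only a limit of the assay, > 100000 nM.
Compound 3, `COc1cccc(-c2nnc(Cn3nnc4ccccc43)o2)c1`: in this assay compound 3 gives only a limit of the assay, > 100000 nM.

All three measured compounds share one core and differ only in the group on the six-membered ring. Compound 2 differs from compound 1 in how the same atoms are joined: 4-bromophenyl in place of 3-bromophenyl on an aromatic carbon. That rearrangement gives a step that the two limits leave unreadable from compound 1 to compound 2. Compound 3 differs from compound 1 by methoxy in place of bromo on an aromatic carbon, and that change gives a step that the two limits leave unreadable from compound 1 to compound 3. Neither step can be read, since every value sits at the limit of > 100000 nM in this assay, at which 3 of the 3 values shown sit.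

Compound 4, `COc1ccc(-c2nnc(Cn3nnc4ccccc43)o2)cc1`, has not yet been measured in this assay. It differs from compound 2 by methoxy in place of bromo on an aromatic carbon. For the measured compounds named here, this is the same kind of change as the one from compound 1 to compound 3, though not the same: there the methoxy sits meta to a large group, here it sits para to a large group.

For compound 4 the expected step is a number no higher from compound 2 to compound 4 (the limit leaves the size open), an expectation that rests on the step from compound 1 to compound 3 being a step that the two limits leave unreadable from compound 1 to compound 3 and on all three shown values sitting at the limit of > 100000 nM in this assay, at which 3 of the 3 values shown sit. Compound 4 is therefore estimated at 100000 nM, most likely again reported only as a limit, within 50000 nM to 300000 nM.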

Compound 4, half-maximal cytotoxic concentration: > 100000 nM
Compound 4: no number, only a limit; the forecaster's own chance of this, stated with the estimate: 85%; the middle value lies on the limit itself.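

In this assay compound 4 gives > 100000 nM as a limit of the assay, not a number. Compound 2 gives a limit as well, so no step can be read between compound 2 and compound 4, and all the values share one limit: the limit of > 100000 nM in this assay, at which 4 of the 4 values shown sit. The compounds shown leave open how much of each compound these cells tolerate, and whether swapping bromo for methoxy or moving the group changes that tolerance at all.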